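Urea Series: Changing the Aryl Group on the Cyclopentane

The source may hold more compounds than are shown below. What is called first, only, known or untested is meant among the compounds shown, and "the series" means these compounds.

Compound 1, `CC(C)c1cccc(C(C)C)c1NC(=O)NCC1(c2ccc(C(C)(C)C)cc2)CCCC1`, gives 63 nM in an assay on microsomes for inhibition of acyl-CoA:cholesterol acyltransferase (Oryctolagus cuniculus); on this read-out lower numbers stand for stronger inhibition and higher numbers for weaker inhibition. Compound 2, `CC(C)c1cccc(C(C)C)c1NC(=O)NCC1(c2ccc(C(F)(F)F)cc2)CCCC1`, gives 66 nM. Compound 3, `CC(C)c1cccc(C(C)C)c1NC(=O)NCC1(c2ccc([N+](=O)[O-])cc2)CCCC1`, gives 131 nM.

Compound 3 stands at the highest number of the three in this assay. The step of a 2.1-fold higher number from compound 1 to compound 3 (0.32 log units; beyond the scatter) is modest, while the step of a 2.0-fold higher number from compound 2 to compound 3 (0.30 log units; within the scatter) stays within the scatter, so compound 3 is not clearly set apart from compound 2.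

Compound 4, `CC(C)c1cccc(C(C)C)c1NC(=O)NCC1(c2cccc(N)c2)CCCC1`, differs from compound 3 in one place: 3-aminophenyl in place of 4-nitrophenyl on a saturated ring carbon. The measured steps all exchange one group for another on the same aromatic ring, and the step of a 1.0-fold higher number from compound 1 to compound 2 (0.02 log units; within the scatter) shows that two of these exchanges barely move the number. Among the compounds with values here, none of them brings in a hydrogen-bond donor or an aminophenyl group, so no measured step bears directly on this change, and the expectation rests on the narrow spread seen so far with added uncertainty. Compound 4 is therefore estimated at 250 nM, with a range from 80 nM to 800 nM, which is expected to amount to a 1.9-fold higher number from compound 3 to compound 4 (0.28 log units; within the scatter).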

Compound 4, half-maximal inhibitory concentration: 21 nM
Estimate against measurement, compound 4: 12-fold (1.08 log units) above, outside the stated range (below it).
By their numbers in this assay, from the lowest: compound 4; then compounds 1, 2 and 3 (each within the scatter of the next, the first and the last beyond it).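

Unlike the earlier exchanges on this ring, which stayed close together, 3-aminophenyl on the saturated ring carbon gives a clear drop in this assay, with a 6.2-fold lower number from compound 3 to compound 4 (0.80 log units; beyond the scatter) and a 3.1-fold lower number from compound 2 to compound 4 (0.50 log units; beyond the scatter) and a 3.0-fold lower number from compound 1 to compound 4 (0.48 log units; beyond the scatter) as its three steps. All three lie beyond the scatter, so compound 4 has the lowest number of the four, and this position can therefore shift inhibition further than the tert-butyl, trifluoromethyl and nitro compounds alone suggested. Nothing measured here explains why the number falls.

The new group differs from the others in both its identity and where it sits on the phenyl ring, and these compounds cannot separate those two changes. Going by these compounds, whether a hydroxyl or a methylamino group in place of the amine would keep the number this low also remains open.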